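A few compounds are considered here, and "the series" means these few. Any claim that something is new, unique, unknown or untested is made for them only; others in the source may bear on it.

Of the compounds shown here, three of a shared core have been tested in a functional assay on M14 cells (Homo sapiens) for inhibition, read by sulforhodamine B assay, with a stated time of 48 h; on this read-out higher numbers stand for weaker inhibition of growth and lower numbers for stronger inhibition of growth. Compound 1 `Nc1cc(N)c2nc(-c3ccccc3)c(NCc3ccc(Cl)c(Cl)c3)nc2c1` gives 15800 nM, the lowest of the three numbers and so the strongest inhibition of growth among them. Compound 2 `CCOC(=O)[C@H](CCC(=O)O)NC(=O)c1ccc(Sc2nc3cc(N)cc(N)c3nc2-c2ccccc2)cc1`, which carries a different side arm on the core, gives 33100 nM. Compound 3 `CCOC(=O)[C@H](CCC(=O)O)NC(=O)c1ccc(Oc2nc3cc(N)cc(N)c3nc2-c2ccccc2)cc1` differs from compound 2 only in the atom that joins that arm to the core; in this assay compound 3 gives 39800 nM. Both of these values lie beyond the usual scatter above the value of compound 1.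

Compound 4 `Nc1cc(N)c2nc(-c3ccccc3)c(NCc3ccc(F)cc3)nc2c1` has not yet been measured. It differs from compound 1 in one place: 4-fluorophenyl in place of 3,4-dichlorophenyl on a saturated chain carbon bound to a nitrogen on an aromatic ring. Among the compounds with values here, no pair among the measured compounds shows this change, so its effect can only be guessed. The change keeps the same kind of group in the same place, so a step of modest size is expected in this assay, if anything toward weaker inhibition, and the step from compound 1 to compound 4 is estimated as a 1.6-fold higher number from compound 1 to compound 4 (0.20 log units; within the scatter). For compound 4 a value of 25000 nM is expected, in a range from 8000 nM to 80000 nM.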

Compound 4, concentration for 50% growth inhibition: 23400 nM
Estimate against measurement, compound 4: 1.1-fold (0.03 log units) above; measured number inside the range.
By their numbers in this assay, from the lowest: compounds 1, 4, 2 and 3 (each within the scatter of the next, the first and the last beyond it).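

Swapping 3,4-dichlorophenyl for 4-fluorophenyl on a saturated chain carbon bound to a nitrogen on an aromatic ring gives, in this assay, a 1.5-fold higher number from compound 1 to compound 4 (0.17 log units; within the scatter), the only step shown at this position. Losing both chlorine atoms and gaining one fluorine therefore leaves no difference that can be told from the scatter of repeated measurements. At this position, then, these two halogen-bearing rings cannot be separated on growth inhibition, although both compounds read only in a weak range.

Still open, from the compounds shown here alone, is whether the position responds to a change of another kind, such as an amine or a carboxylic acid on the ring, a ring with no halogen at all, or a longer chain in place of the single carbon of the benzyl link. Nothing measured here bears on why the two groups read alike.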